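The source may report more compounds than this note shows. Statements on the series, on what has been measured and on what is new or still open speak of the compounds shown alone.

Working notes on the series. The three measured compounds share one core and differ only in the aryl group on a saturated ring carbon. In a functional assay on Ehrlich cells (Mus musculus) for cytotoxicity, tested at 50 ug/mL (on this read-out lower numbers stand for a weaker effect and higher numbers for a stronger effect at the one concentration tested), compound 1 `COc1cc(N2C(N)=C(C#N)C(c3ccccc3O)C3=C2CC(C)(C)CC3=O)cc(OC)c1OC` gives 2%. Compound 2 `COc1cc(N2C(N)=C(C#N)C(c3cccc([N+](=O)[O-])c3)C3=C2CC(C)(C)CC3=O)cc(OC)c1OC` gives 30% in this assay, and compound 3 `COc1cc(N2C(N)=C(C#N)C(c3ccccc3Cl)C3=C2CC(C)(C)CC3=O)cc(OC)c1OC` gives 20%. Compound 2 holds the highest of the three numbers, though compound 3 lies within the scatter of it; the gap to compound 1 is real: a number 28 percentage points higher from compound 1 to compound 2 (beyond the scatter). The remaining steps are a number 18 percentage points higher from compound 1 to compound 3 (beyond the scatter) and a number 10 percentage points lower from compound 2 to compound 3 (within the scatter).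

Compound 4 `COc1cc(N2C(N)=C(C#N)C(c3ccc(O)cc3)C3=C2CC(C)(C)CC3=O)cc(OC)c1OC` is not yet measured. (4-hydroxyphenyl in place of 3-nitrophenyl on a saturated ring carbon). The step that bears on this is a number 28 percentage points higher from compound 1 to compound 2 (beyond the scatter), where the 3-nitrophenyl replaced a 2-hydroxyphenyl and the number rose by a modest amount. Compound 1 shows how a hydroxyphenyl variant reads in this assay, 2%. Among the measured compounds shown here, no measured step compares 2-hydroxyphenyl with 4-hydroxyphenyl, so that part rests on nothing. A drop beyond the scatter is expected, i.e. a number 22 percentage points lower from compound 2 to compound 4 (beyond the scatter). Compound 4 is estimated at 8% in this assay, with a range of 0% to 25%.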

Compound 4, a percentage reported as activity, at one concentration (the size of the read-out at that concentration, not a potency): 90%
Estimate against measurement, compound 4: 82 percentage points below, and the stated range ends below it.
By their numbers in this assay, from the lowest: compound 1; then compounds 3 and 2 (each within the scatter of the next); then compound 4.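

In this assay, among the compounds shown here, the aryl group on this saturated ring carbon can move the read-out much further than the earlier compounds showed: 4-hydroxyphenyl gives a number 60 percentage points higher from compound 2 to compound 4 (beyond the scatter) against 3-nitrophenyl and a number 70 percentage points higher from compound 3 to compound 4 (beyond the scatter) against 2-chlorophenyl. A hydroxyphenyl group as such does not fix the number, since the change from 2-hydroxyphenyl to 4-hydroxyphenyl gives a number 88 percentage points higher from compound 1 to compound 4 (beyond the scatter), the largest step in the series. No measurement at hand accounts for this result.

The compounds shown leave open whether the hydroxy group of 4-hydroxyphenyl is itself needed, which a methoxy group or an amine in its place would test. On these data alone, with one concentration per compound, the potency of compound 4 also remains unknown.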